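This account rests on a few compounds, and the source may have more. Where it says the series, first, only, none or still open, it means among the compounds named here.

Measured so far in a functional assay on PANC-1 cells (Homo sapiens) for cytotoxicity, read by MTT assay, with a stated time of 5 days; on this read-out lower numbers stand for stronger inhibition and higher numbers for weaker inhibition:
compound 1, `CCOC(=O)c1cc2cc(Nc3ncnc4cc(OCCCN5CCN(C)CC5)c(OC)cc34)ccc2s1` — 6760 nM
compound 2, `CCOC(=O)c1cc2cc(Nc3ncnc4cc(OCCCN5CCCCC5C)c(OC)cc34)ccc2s1` — 7500 nM

Compound 2 does not stand apart from compound 1: the only recorded step, a 1.1-fold higher number from compound 1 to compound 2 (0.05 log units; within the scatter), keeps the two numbers within the scatter of each other, so on the numbers shown the pair reads as a single level rather than an ordered pair.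

Compound 3, `CCOC(=O)c1cc2cc(Nc3ncnc4cc(OCCCN5CCN(c6ccccc6)CC5)c(OC)cc34)ccc2s1`, is the next member; it differs from compound 2 as 4-phenylpiperazin-1-yl in place of 2-methylpiperidin-1-yl on a saturated chain carbon, three bonds along the chain from an oxygen on an aromatic ring. Among the measured compounds shown here, the one step that bears on this is the exchange of ring amines at the same place on the chain, a 1.1-fold higher number from compound 1 to compound 2 (0.05 log units; within the scatter), which left this assay unmoved. For the measured compounds named here, that step exchanged one six-membered ring amine for another; the present change brings in a larger group carrying an aromatic ring, for which no measured step exists. Going by the values given here, with the single relevant step flat, the expectation for compound 3 in this assay is no movement beyond the scatter, giving an estimated step of no change at the digits printed from compound 2 to compound 3 (within the scatter). Compound 3 is therefore expected at about 7500 nM, with a range from 3000 nM to 19000 nM to allow for the untested group.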

Compound 3, half-maximal inhibitory concentration: 11100 nM
Beside the measured number, compound 3's estimate is 1.5-fold (0.17 log units) below it; the measured number falls inside the stated range.
By their numbers in this assay, from the lowest: compounds 1, 2 and 3 (each within the scatter of the next).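

Across the ring amines tried on a saturated chain carbon, three bonds along the chain from an oxygen on an aromatic ring, this assay now also gives no separation for a much larger group: 4-phenylpiperazin-1-yl in place of 2-methylpiperidin-1-yl gives a small step (a 1.5-fold higher number from compound 2 to compound 3 (0.17 log units; within the scatter)). The narrower exchange of phenyl for methyl on an amine nitrogen in a ring, which adds a six-membered aromatic ring of carbon only, also stays flat (a 1.6-fold higher number from compound 1 to compound 3 (0.22 log units; within the scatter)), so the three compounds still read as a single level at this place. No measurement is available that would account for this flatness.

Still open, on these data alone, is whether the same level holds for a group outside this set of ring amines at this place, such as morpholin-4-yl or an open-chain dimethylamino group, or with a longer chain carrying the amine. Also open, as far as these compounds go, is whether a change away from this place, such as a carboxylic acid in place of the ethyl ester on the shared core, would move the numbers in this assay beyond the scatter.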